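The source may hold more compounds than are shown below. What is called first, only, known or untested is meant among the compounds shown, and "the series" means these compounds.

Measured so far in a functional assay on WM164 cells (Homo sapiens) for antiproliferative activity, read by sulforhodamine B assay, with a stated time of 48 h (on this read-out higher numbers stand for weaker inhibition and lower numbers for stronger inhibition), are two compounds:
Compound 1 `CCCCCCCCCCNC(=O)[C@@H]1CSC(c2cc(OC)c(OC)c(OC)c2)N1` gives 2100 nM here
Compound 2 `CCCCCCCCCCCCCCNC(=O)[C@@H]1CSC(c2cc(OC)c(OC)c(OC)c2)N1` gives 1600 nM here

Among the measured compounds shown here, compound 2 stands level with compound 1 within the scatter, and the one measured step of a 1.3-fold lower number from compound 1 to compound 2 (0.12 log units; within the scatter) concerns the chain only. Compound 3 `CCCCCCCCCCCCCCNC(=O)[C@H]1CSC(c2cc(OC)c(OC)c(OC)c2)N1` differs from compound 2 as follows: the two compounds have the same atoms and bonds; at least one stereo element is drawn with a configuration in one of them and without one in the other: 1 of 2 stereo elements differ; a stereocentre at a saturated ring carbon is drawn R in compound 2 and S in compound 3 and nothing else changes. For the measured compounds named here, no measured step touches this stereocentre, so none bears on it directly, and no shift beyond the scatter is expected in this assay in either direction. The expected step of a 1.1-fold higher number from compound 2 to compound 3 (0.05 log units; within the scatter) is an estimate only. For compound 3 the estimate is 1800 nM and the expected range runs from 800 nM to 4000 nM on the same scale.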

Compound 3, half-maximal inhibitory concentration: 1100 nM
For compound 3 the middle estimate is 1.6-fold (0.21 log units) above the measured one, within the range that was stated.
By their numbers in this assay, from the lowest: compounds 3, 2 and 1 (each within the scatter of the next).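

In this assay, with the chain held constant, redrawing the stereocentre at the saturated ring carbon from R to S gives a 1.5-fold lower number from compound 2 to compound 3 (0.16 log units; within the scatter), so the two stand level. Among the compounds shown here, this is the first measured change at this position, and like the chain step before it, it stays within the scatter. The comparison carries one reservation: the fact that one of compounds 2 and 3 is drawn with a defined configuration and the other without, at the place where they differ

The compounds shown leave open whether the same change behaves alike on the shorter chain of compound 1. They also leave open whether a carboxylic acid or an amine in place of the amide chain would shift the number beyond the scatter.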